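The source may hold more compounds than are shown below. What is called first, only, known or untested is meant among the compounds shown, and "the series" means these compounds.

Measured compounds in an in vitro assay on UC11MG cells for binding affinity to Substance-P receptor (Homo sapiens), read by radioligand binding; on this read-out higher numbers stand for weaker inhibition and lower numbers for stronger inhibition:
- compound 1 `CN(Cc1cc(C(F)(F)F)cc(C(F)(F)F)c1)C(=O)c1cnc2ccccc2c1-c1ccccc1` gives 0.03 nM
- compound 2 `NCc1nc2ccccc2c(-c2ccccc2)c1C(=O)NCc1cc(C(F)(F)F)cc(C(F)(F)F)c1` gives 0.0017 nM
- compound 3 `CN(C)Cc1nc2ccccc2c(-c2ccccc2)c1C(=O)NCc1cc(C(F)(F)F)cc(C(F)(F)F)c1` gives 0.22 nM

Compound 3 stands highest of the three numbers in this assay; compound 1 sits nearest, compound 2 furthest, both beyond the scatter. Compound 4 `CC(C)(C)[Si](C)(C)OCc1nc2ccccc2c(-c2ccccc2)c1C(=O)NCc1cc(C(F)(F)F)cc(C(F)(F)F)c1` is not yet measured. It differs from compound 3 by a group of 8 heavy atoms (6 carbon, 1 oxygen, 1 silicon; no ring) in place of a group of 3 heavy atoms (2 carbon, 1 nitrogen; no ring), on a saturated chain carbon bound to an aromatic carbon. Among the compounds with values here, the only measured step at this position is a 130-fold higher number from compound 2 to compound 3 (2.11 log units; beyond the scatter), which shows that changing the group on this saturated chain carbon can move the number a long way. That step replaced amino with dimethylamino; the group entering in compound 4 has neither of these, so it bears on the change only in showing how sensitive this position is. Within the data shown here, no measured pair shows a group of this kind. A further step in the direction of higher numbers is expected, of moderate size, a 2.7-fold higher number from compound 3 to compound 4 (0.44 log units; beyond the scatter). For compound 4 the estimate in this assay is 0.6 nM, with a range from 0.12 nM to 3 nM.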

Compound 4, half-maximal inhibitory concentration: 17 nM
Compound 4: the middle estimate sits 28-fold (1.45 log units) below what was measured, outside the stated range (above it).
By their numbers in this assay, from the lowest: compound 2; then compound 1; then compound 3; then compound 4.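

In this assay the saturated chain carbon bound to an aromatic carbon now has a reading for a group without nitrogen, and the number climbs further, with a 77-fold higher number from compound 3 to compound 4 (1.89 log units; beyond the scatter). Measured from the amino group, the whole span is a 10000-fold higher number from compound 2 to compound 4 (4.00 log units; beyond the scatter), so this position's sensitivity extends well beyond the change from amino to dimethylamino. Across these three compounds, the order from lowest number to highest runs amino, dimethylamino, then the group of 8 heavy atoms, and no data here explain that order.

The compounds shown leave open how a hydroxyl or methoxy group would read on this carbon, which would separate the oxygen from the silicon-bearing remainder of the group. They also leave open where a methylamino group would fall relative to amino and dimethylamino.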